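This account rests on a few compounds, and the source may have more. Where it says the series, first, only, none or still open, it means among the compounds named here.

Measured so far in a functional assay on HaCaT cells (Homo sapiens) for antiproliferative activity, read by sulforhodamine B assay, with a stated time of 3 days; on this read-out higher numbers stand for weaker inhibition and lower numbers for stronger inhibition:

- compound 1 `COC(=O)c1cc(CCc2cccc(OC)c2)ccc1O`: 37000 nM
- compound 2 `COC(=O)c1cc(CCc2cccc(OC)c2OC)ccc1O`: 33000 nM

For the measured compounds named here, with 33000 nM, compound 2 cannot be told apart from compound 1, the only other compound measured. Compound 3 `COC(=O)c1cc(CCc2c(OC)ccc(OC)c2OC)ccc1O` is built from compound 2 by one change: methoxy in place of hydrogen on an aromatic carbon. Going by the values given here, the only measured step of the same kind, also methoxy in place of hydrogen on an aromatic carbon, is a 1.1-fold lower number from compound 1 to compound 2 (0.05 log units; within the scatter). That step involves a different carbon, and one step is thin evidence, so the expectation is loose. On this evidence, no step beyond the scatter is expected in this assay, in either direction. The estimate amounts to an expected 1.1-fold lower number from compound 2 to compound 3 (0.04 log units; within the scatter). Compound 3 is expected to give about 30000 nM, with an estimated range from 12000 nM to 70000 nM.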

Compound 3, half-maximal inhibitory concentration: 3500 nM
The estimate for compound 3 lay 8.6-fold (0.93 log units) above the measured number; measured number outside the range, below it.
By their numbers in this assay, from the lowest: compound 3; then compounds 2 and 1 (each within the scatter of the next).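

In this assay, the same swap of hydrogen for methoxy does not count equally at every carbon of this ring. At the carbon that is ortho to a large group, meta to a methoxy group and para to a methoxy group, it gives a 9.4-fold lower number from compound 2 to compound 3 (0.97 log units; beyond the scatter) and so brings a real gain in inhibition, whereas at a different carbon it gave a 1.1-fold lower number from compound 1 to compound 2 (0.05 log units; within the scatter) and so no clear change. Nothing available here accounts for this difference between the two carbons.

The compounds shown leave open whether a smaller or different group at this carbon, such as a hydroxyl, a fluorine or an amine, would do the same. They also leave open whether this methoxy group would give the same step without the other two methoxy groups on the ring.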